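This account rests on a few compounds, and the source may have more. Where it says the series, first, only, none or still open, it means among the compounds named here.

Measured compounds:
- Compound 1, `CCCCCOc1nc(N)c2nc(O)n(Cc3ccccc3)c2n1`: 0.01 uM
- Compound 2, `CCCNc1nc(N)c2nc(O)n(Cc3ccccc3)c2n1`: 0.1 uM

Both values come from a functional assay (spleen, spleen) for activation, with Mus musculus as the target; on this read-out higher numbers stand for an effect only at larger amounts of compound and lower numbers for an effect already at smaller amounts. Compound 2 stands highest of the two numbers; its nearest neighbour is compound 1, and the step of a 10-fold higher number from compound 1 to compound 2 (1.00 log units; beyond the scatter) lies beyond the scatter.

Compound 3, `CCCCCSc1nc(N)c2nc(O)n(Cc3ccccc3)c2n1`, is not yet measured. It differs from compound 2 by pentylsulfanyl in place of propylamino on an aromatic carbon. Among the measured compounds shown here, the only measured step that bears on this change is a 10-fold higher number from compound 1 to compound 2 (1.00 log units; beyond the scatter), in which propylamino replaced pentyloxy; the step from compound 2 to compound 3 runs the other way in that respect, as propylamino leaves and a pentyl chain attached through sulfur enters, so compound 3 resembles compound 1 more than compound 2 does. For the measured compounds named here, no measured pair shows an oxygen to sulfur exchange, so the exact size is uncertain.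

On this basis a lower number is expected for compound 3 in this assay, of a size comparable to the measured step, and compound 3 is expected to give 0.02 uM, with a range from 0.005 uM to 0.1 uM. This corresponds to an expected step of a 5.0-fold lower number from compound 2 to compound 3 (0.70 log units; beyond the scatter).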

Compound 3, minimum effective concentration: 10 uM
Estimate against measurement, compound 3: 500-fold (2.70 log units) below, and the stated range ends below it.
By their numbers in this assay, from the lowest: compound 1; then compound 2; then compound 3.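

In this assay, the atom linking the pentyl chain to the aromatic carbon between two ring nitrogen atoms proves decisive, since pentylsulfanyl in place of pentyloxy leaves the chain in place and still gives a 1000-fold higher number from compound 1 to compound 3 (3.00 log units; beyond the scatter). The position is therefore far less tolerant of this change than the earlier pair suggested: pentylsulfanyl in place of propylamino gives a 100-fold higher number from compound 2 to compound 3 (2.00 log units; beyond the scatter), whereas the earlier exchange of pentyloxy for propylamino gave only a 10-fold higher number from compound 1 to compound 2 (1.00 log units; beyond the scatter), so a pentyl chain alone does not secure an effect at small amounts of compound. Nothing available explains why the sulfur-linked chain behaves so differently from the oxygen-linked one.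

Linking atom and chain length change together between propylamino and either pentyl compound, so the three compounds do not separate the contribution of each. Pentylamino, propoxy and propylsulfanyl groups at this position would pull the two apart, and would show whether the high number of compound 3 holds for sulfur-linked chains in general or belongs to the pentylsulfanyl group alone.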